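The source may hold more compounds than are shown below. What is called first, only, known or untested is meant among the compounds shown, and "the series" means these compounds.

Compound 2 `COc1cc(/C=C/C(=O)c2ccc(OCCn3cc(CN4C(=O)/C=C/C(C)(C)C/C=C(\C)CC/C=C/4C)nn3)cc2O)cc(OC)c1OC` gives 2.61 ug/mL in a functional assay on SW480 cells (Homo sapiens) for antiproliferative activity (a higher number here means a weaker inhibitor, a lower number a stronger inhibitor), which stands with compound 1 `COc1ccc(/C=C/C(=O)c2ccc(OCCn3cc(CN4C(=O)/C=C/C(C)(C)C/C=C(\C)CC/C=C/4C)nn3)cc2O)cc1` at 3.24 ug/mL; the step of a 1.2-fold lower number from compound 1 to compound 2 (0.09 log units; within the scatter) is within the scatter. Compound 3 `C/C1=C\CC(C)(C)/C=C/C(=O)N(Cc2cn(CCOc3ccc(C(=O)/C=C/c4ccc(C(C)C)cc4)c(O)c3)nn2)/C(C)=C/CC1` carries the change (4-isopropylphenyl in place of 3,4,5-trimethoxyphenyl on a double-bonded chain carbon bound to a double-bonded chain carbon). Going by the values given here, the only measured step that also swaps the aryl group at this place stayed within the scatter, so no movement beyond the scatter is expected here either, and the estimated step of a 1.1-fold higher number from compound 2 to compound 3 (0.06 log units; within the scatter) follows because a 1.2-fold lower number from compound 1 to compound 2 (0.09 log units; within the scatter) is within the scatter. Compound 3 is therefore expected to come out at about 3 ug/mL, somewhere between 1.4 ug/mL and 6.5 ug/mL.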

Compound 3, half-maximal inhibitory concentration: 0.85 ug/mL
For compound 3 the middle estimate is 3.5-fold (0.55 log units) above the measured one; the whole stated range lies above it.
By their numbers in this assay, from the lowest: compound 3; then compounds 2 and 1 (each within the scatter of the next).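

In this assay this position proves sensitive to the choice of aryl group: 4-isopropylphenyl in place of 3,4,5-trimethoxyphenyl gives a 3.1-fold lower number from compound 2 to compound 3 (0.49 log units; beyond the scatter), and isopropyl in place of methoxy on an aromatic carbon gives a 3.8-fold lower number from compound 1 to compound 3 (0.58 log units; beyond the scatter). Of the aryl groups shown, only the one without oxygen separates from the others beyond the scatter. No measurement here accounts for this gain. The compounds shown leave open whether a longer chain such as butyl would keep the lower number, and how an amine or a carboxylic acid on that aromatic carbon would fare.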